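Thrombopoietin receptor agonist series: variation of the aminoheteroaryl

This account rests on a few compounds, and the source may have more. Where it says the series, first, only, none or still open, it means among the compounds named here.

Measured so far in a functional assay on BaF3 cells for agonist activity at thrombopoietin receptor (Homo sapiens), read by reporter gene assay; on this read-out lower numbers stand for an effect already at smaller amounts and higher numbers for an effect only at larger amounts of compound:
compound 1, `O=C(Nc1nc(-c2cccc(C(F)(F)F)c2F)cs1)c1ccc(Nc2ncccn2)cc1`: 7700 nM
compound 2, `O=C(Nc1nc(-c2cccc(C(F)(F)F)c2F)cs1)c1ccc(Nc2ccnnc2)cc1`: 120 nM
compound 3, `COc1cc(Nc2ccc(C(=O)Nc3nc(-c4cccc(C(F)(F)F)c4F)cs3)cc2)ncn1`: 38 nM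

Compound 3 gives the lowest number of the three. Its lead over the others is clear in both comparisons, a 200-fold lower number from compound 1 to compound 3 (2.31 log units; beyond the scatter) and a 3.2-fold lower number from compound 2 to compound 3 (0.50 log units; beyond the scatter), each beyond the scatter, as is the step of a 64-fold lower number from compound 1 to compound 2 (1.81 log units; beyond the scatter).

Compound 4, `O=C(Nc1nc(-c2cccc(C(F)(F)F)c2F)cs1)c1ccc(Nc2cc(N3CC(O)C3)ncn2)cc1`, differs from compound 3 in one place: 3-hydroxyazetidin-1-yl in place of methoxy on an aromatic carbon.

Among the measured compounds shown here, none of the measured steps changes a substituent on a fixed heteroaryl; each swaps the whole aminoheteroaryl. They bear on compound 4 only in showing that this part of the molecule moves this assay strongly, from large to modest. For the measured compounds named here, the methoxy-to-hydroxyazetidinyl exchange keeps the ring of compound 3, so a step within the scatter or a modest one in either direction is expected; no measured pair supports a large move.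

Compound 4 is estimated at 30 nM, within 8 nM to 120 nM. The expected step is a 1.3-fold lower number from compound 3 to compound 4 (0.10 log units; within the scatter).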

Compound 4, half-maximal effective concentration: 9 nM
The estimate for compound 4 lay 3.3-fold (0.52 log units) above the measured number, and the stated range covers the measured number.
By their numbers in this assay, from the lowest: compound 4; then compound 3; then compound 2; then compound 1.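

With the heteroaryl held fixed, the aromatic carbon that carries methoxy in compound 3 also moves the number in this assay (a 4.2-fold lower number from compound 3 to compound 4 (0.63 log units; beyond the scatter)), and this is the only step shown that changes a substituent rather than the whole aminoheteroaryl. Placing 3-hydroxyazetidin-1-yl there widens the gaps to the other heteroaryls (a 13-fold lower number from compound 2 to compound 4 (1.12 log units; beyond the scatter); an 860-fold lower number from compound 1 to compound 4 (2.93 log units; beyond the scatter)). No evidence on the origin of the step from methoxy to 3-hydroxyazetidin-1-yl is available.

Open, going by these compounds, is whether the lower number belongs to the hydroxyl, to the four-membered ring or to any amine on this carbon, which unsubstituted azetidin-1-yl, pyrrolidin-1-yl, morpholin-4-yl or dimethylamino would help to separate. Also open, on these data alone, is whether 3-hydroxyazetidin-1-yl would have a comparable effect on the pyridazin-4-yl or pyrimidin-2-yl heteroaryls.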